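The source may report more compounds than this note shows. Statements on the series, on what has been measured and on what is new or still open speak of the compounds shown alone.

Measured so far:
Compound 1, `CC1(C)[C@H]2CC[C@]1(C)N(Cc1cn(-c3ccc(Cl)cc3)nn1)C(=O)C2`: in a functional assay on LoVo cells (Homo sapiens) for inhibition, read by MTT assay, with a stated time of 24 h (a lower number here means a stronger inhibitor, a higher number a weaker inhibitor), compound 1 gives 160 nM.
Compound 2, `COc1ccccc1-n1cc(CN2C(=O)C[C@@H]3CC[C@@]2(C)C3(C)C)nn1`: in this assay compound 2 gives 70 nM.
Compound 3, `COc1ccc(-n2cc(CN3C(=O)C[C@@H]4CC[C@@]3(C)C4(C)C)nn2)cc1`: in this assay compound 3 gives 70 nM.

Compound 3 stands level with compound 2 at the digits shown, and the two together carry the lowest numbers of the three. Compound 1 lies furthest from compound 3; the step of a 2.3-fold lower number from compound 1 to compound 3 (0.36 log units; beyond the scatter) is beyond the scatter. The step of no change at the digits printed from compound 2 to compound 3 (within the scatter) stays within the scatter.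

Compound 4, `CC1(C)[C@H]2CC[C@]1(C)N(Cc1cn(-c3ccccc3Cl)nn1)C(=O)C2`, is the next to be measured. Relative to compound 3 the change is 2-chlorophenyl in place of 4-methoxyphenyl on an aromatic nitrogen. Among the compounds with values here, two measured steps bear on this. The step of a 2.3-fold lower number from compound 1 to compound 3 (0.36 log units; beyond the scatter) shows that methoxy against chloro on the phenyl ring was worth a modest step in this assay, so reversing it should be worth a modest step the other way. The step of no change at the digits printed from compound 2 to compound 3 (within the scatter) shows that 2-methoxyphenyl against 4-methoxyphenyl made no difference beyond the scatter, so the 2-chlorophenyl of compound 4 is expected to behave much like the 4-chlorophenyl of compound 1. Compound 4 is therefore expected to show a modest rise, estimated as a 1.9-fold higher number from compound 3 to compound 4 (0.27 log units; within the scatter). For compound 4 the estimate in this assay is 130 nM, with a range from 55 nM to 300 nM; the range is kept wide because only compound 1, with 160 nM, carries a chloro group.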

Compound 4, half-maximal inhibitory concentration: 190 nM
Compound 4: middle estimate off by 1.5-fold (0.16 log units), on the low side; low and high end bracket the measured number.
By their numbers in this assay, from the lowest: compounds 2 and 3 (each within the scatter of the next); then compounds 1 and 4 (each within the scatter of the next).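

Replacing 4-chlorophenyl with 2-chlorophenyl on the aromatic nitrogen gives a 1.2-fold higher number from compound 1 to compound 4 (0.07 log units; within the scatter), so in this assay the two chloro placements are not told apart, just as the two methoxy placements were not. The difference in this small set therefore follows the identity of the group on the phenyl ring rather than its placement, with a 2.7-fold higher number from compound 3 to compound 4 (0.43 log units; beyond the scatter) and a 2.7-fold higher number from compound 2 to compound 4 (0.43 log units; beyond the scatter) both separating a methoxyphenyl compound from the 2-chlorophenyl compound. Methoxy against chloro now reads as a repeatable modest step, seen at both placements on the phenyl ring rather than in a single pair: the same change on two cores in this assay, a 2.3-fold lower number (0.36 log units; beyond the scatter) from compound 1 to compound 3 and a 2.7-fold lower number (0.43 log units; beyond the scatter) from compound 4 to compound 2, 1.2-fold (0.07 log units) apart, within the scatter of two such steps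

The compounds shown carry only chloro and methoxy on the phenyl ring, so it remains open whether a hydroxyl, an amine, a carboxylic acid or a longer alkoxy chain would follow the methoxy compounds, the chloro compounds or neither. On these data alone, the unsubstituted phenyl also remains open as a reference point, and without it the step between chloro and methoxy cannot be divided into a contribution from each group.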